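Swapping methoxy for methyl on the chalcone aryl ring

The source may report more compounds than this note shows. Statements on the series, on what has been measured and on what is new or still open speak of the compounds shown alone.

Measured compounds:
- Compound 1, `COc1ccc(C(=O)/C=C/c2cc(-c3ccc(OC)c(OC)c3)n3nc(-c4ccccc4)cc3n2)cc1OC`: 2600 nM
- Compound 2, `COc1cc(-c2cc(/C=C/C(=O)c3ccc(C)c(C)c3)nc3cc(-c4ccccc4)nn23)cc(OC)c1OC`: 13500 nM
- Compound 3, `COc1ccc(/C=C/C(=O)c2cc(-c3ccc(OC)c(OC)c3)n3nc(-c4ccccc4)cc3n2)cc1`: 22000 nM

All three were tested in a functional assay on MDA-MB-231 cells (Homo sapiens) for antiproliferative activity, read by MTT assay, with a stated time of 24 h; a higher number here means a weaker inhibitor, a lower number a stronger inhibitor. Compound 3 has the highest number of the three, meaning it is the weakest inhibitor in this set. Compared with compound 2, the gap is within the usual scatter, so the two cannot be ordered with confidence. Compared with compound 1, the gap is beyond the scatter, and compound 1 is clearly the stronger inhibitor.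

The unmeasured compound 4, `COc1ccc(-c2cc(C(=O)/C=C/c3ccc(C)cc3)nc3cc(-c4ccccc4)nn23)cc1OC`, differs from compound 3 in one place: methyl in place of methoxy on an aromatic carbon. Among the compounds with values here, no pair of measured compounds shows this same change, so there is no direct guide to its effect. Since nothing in the data points in either direction, the step is expected to stay within the scatter, with a step of a 1.1-fold higher number from compound 3 to compound 4 (0.04 log units; within the scatter). Compound 4 is estimated at 24000 nM, with a range from 10000 nM to 60000 nM.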

Compound 4, half-maximal inhibitory concentration: 22600 nM
Beside the measured number, compound 4's estimate is 1.1-fold (0.03 log units) above it, and the stated range covers the measured number.
By their numbers in this assay, from the lowest: compound 1; then compounds 2, 3 and 4 (each within the scatter of the next).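

In this assay putting methyl in place of methoxy on this aromatic carbon, para to a large group, gives a 1.0-fold higher number from compound 3 to compound 4 (0.01 log units; within the scatter) and so the two numbers cannot be told apart. Within the data shown here, this is the first direct reading of this swap, as the earlier compounds held no pair that differs in this way. It shows that, in this pair, the read-out does not depend on which of these two groups sits here, and no measurement at hand explains why.

From the compounds shown here alone, whether that tolerance extends to other groups at this position, such as an amine, a carboxylic acid or a longer chain, stays open. Also open, going by these compounds, is whether the same swap would read alike on the other aromatic rings of the shared core.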